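Removing a methylcarbamoyl group from an inactive amine

This account rests on a few compounds, and the source may have more. Where it says the series, first, only, none or still open, it means among the compounds named here.

Compound 1 `Cc1cc(NC(C)c2ccc(F)cc2)n2ncc(-c3ccccn3)c2n1`: > 27100 nM; > 27100 nM (2 entries)
Compound 2 `CNC(=O)C(Nc1cc(C)nc2c(-c3ccccn3)cnn12)c1ccc(F)cc1`: > 27100 nM

In an assay on CHO cells with G-protein coupled receptor 39 (Homo sapiens) as the target, read by calcium flux (on this read-out higher numbers stand for an effect only at larger amounts of compound and lower numbers for an effect already at smaller amounts), compound 1 gives only a limit, > 27100 nM; > 27100 nM (2 entries), and no single number. Compound 2 likewise stands only at a limit, > 27100 nM, so its place on the scale is a bound rather than a number. Among the measured compounds shown here, for compound 2 the one point of evidence is the limit of > 27100 nM in this assay, at which 1 of the 2 values shown sits, and a further entry carries no number either. Compound 3 `Cc1cc(NCc2ccc(F)cc2)n2ncc(-c3ccccn3)c2n1` differs from compound 2 in one place: hydrogen in place of methylcarbamoyl on a saturated chain carbon bound to an aromatic carbon and a nitrogen on an aromatic ring. For the measured compounds named here, no pair of measured compounds differs in a single place, so no measured step is available. Compound 3 is expected to remain near the same bound, with the step that the limit leaves unreadable from compound 2 to compound 3 expected to be none beyond the scatter. Compound 3 is therefore estimated at 30000 nM, between 8000 nM and 100000 nM, most likely again reported only as a limit.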

Compound 3, half-maximal effective concentration: > 27100 nM
Compound 3 gave a limit, no number; the forecaster's own chance of this, stated with the estimate: 75%; the middle value is on the limit's open side.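

Among the compounds shown here, compound 2 and compound 3 each give only a limit, so no step between them can be read. The compounds shown leave open where any of them would fall on the scale of this assay, and whether methylcarbamoyl matters there at all: the limit of > 27100 nM in this assay, at which 2 of the 3 values shown sit.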